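Triazole series: carbamoyl arm in place of methylbenzyl

A few compounds are considered here, and "the series" means these few. Any claim that something is new, unique, unknown or untested is made for them only; others in the source may bear on it.

compound 1 `COc1ccc(-n2c(SCc3ccc(C)cc3)nnc2-c2cc(OC)c(OC)c(OC)c2)cc1`: > 60000 nM
compound 2 `COc1cc(-c2nnc(SCc3ccc(C)cc3)n2-c2ccc(N(C)C)cc2)cc(OC)c1OC`: 27500 nM

In a functional assay on HT-29 cells (Homo sapiens) for inhibition, read by MTT assay, with a stated time of 48 h (a lower number here means a stronger inhibitor, a higher number a weaker inhibitor), compound 1 gives only a limit, > 60000 nM. That value is the limit of > 60000 nM in this assay, at which 1 of the 2 values shown sits. Compound 2 gives 27500 nM in this assay, the only number shown in the series. For the measured compounds named here, the single measured step is an at least 2.1-fold lower number from compound 1 to compound 2 (0.33 log units; beyond the scatter). Compound 3 `COc1ccc(NC(=O)CSc2nnc(-c3cc(OC)c(OC)c(OC)c3)n2-c2ccc(N(C)C)cc2)cc1` differs from compound 2 by (4-methoxyphenyl)carbamoyl in place of 4-methylphenyl on a saturated chain carbon bound to a sulfur. Going by the values given here, that place is untouched by the measured step, so no measured step bears on this change. The expected step of a 1.1-fold lower number from compound 2 to compound 3 (0.04 log units; within the scatter) is none beyond the scatter. Compound 3 is estimated at 25000 nM, within 8000 nM to 70000 nM.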

Compound 3, half-maximal inhibitory concentration: 51400 nM
The estimate for compound 3 lay 2.1-fold (0.31 log units) below the measured number, and the stated range covers the measured number.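

In this assay, for the compounds shown here, this is the first reading at this position: (4-methoxyphenyl)carbamoyl in place of 4-methylphenyl on a saturated chain carbon bound to a sulfur gives a 1.9-fold higher number from compound 2 to compound 3 (0.27 log units; within the scatter). Compound 2 and compound 3 therefore stand level, even though the entering group brings a carbonyl and the amide hydrogen. Nothing measured here speaks to a cause for this step.

Open, on these data alone, is whether an amine or a carboxylic acid on that arm, or a longer chain, would move the number beyond the scatter. Also open, as far as these compounds go, is whether the carbamoyl arm reads the same with methoxy in place of dimethylamino on the aromatic carbon.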